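Cyclohexyl in place of the substituted phenyl of compound 3

The source may report more compounds than this note shows. Statements on the series, on what has been measured and on what is new or still open speak of the compounds shown alone.

In a functional assay on MV4-11 cells (Homo sapiens) for antiproliferative activity, read by luminescence and CellTiter-Glo, with a stated time of 72 h (a lower number here means a stronger inhibitor, a higher number a weaker inhibitor), compound 3 `CNc1cc(-c2ccc3cnn(Cc4ccc(OC)c(F)c4)c3c2)cn(C)c1=O` gives 4980 nM as the highest of three numbers, with compound 1 `CNc1cc(-c2ccc3cnn(Cc4ccc(F)cc4)c3c2)cn(C)c1=O` lower at 2390 nM and compound 2 `CNc1cc(-c2ccc3cnn(Cc4ccc(F)c(F)c4)c3c2)cn(C)c1=O` lower still at 320 nM in the same read-out. Compound 4 `CNc1cc(-c2ccc3cnn(CC4CCCCC4)c3c2)cn(C)c1=O` has cyclohexyl in place of 3-fluoro-4-methoxyphenyl on a saturated chain carbon bound to an aromatic nitrogen. Within the data shown here, no measured compound carries a non-aromatic ring in that place, so the evidence is indirect: a 16-fold higher number from compound 2 to compound 3 (1.19 log units; beyond the scatter) is a large step, while a 7.5-fold lower number from compound 1 to compound 2 (0.87 log units; beyond the scatter) and a 2.1-fold higher number from compound 1 to compound 3 (0.32 log units; beyond the scatter) are modest ones. Since compound 3 stands at 4980 nM at the top of the measured span, a modest step to a lower number is expected in this assay here. The estimated step is a 2.5-fold lower number from compound 3 to compound 4 (0.40 log units; beyond the scatter) with wide uncertainty. For compound 4 the estimate is 2000 nM with an expected range from 450 nM to 8000 nM in this read-out.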

Compound 4, half-maximal inhibitory concentration: 2690 nM
Compound 4: the middle estimate sits 1.3-fold (0.13 log units) below what was measured; the range from low to high includes it.
By their numbers in this assay, from the lowest: compound 2; then compounds 1, 4 and 3 (each within the scatter of the next, the first and the last beyond it).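

In this assay, a 1.1-fold higher number from compound 1 to compound 4 (0.05 log units; within the scatter) and a 1.9-fold lower number from compound 3 to compound 4 (0.27 log units; within the scatter) both lie within the scatter, so an aromatic ring is not required in this place to hold the level of those two compounds. The 3,4-difluorophenyl stays apart: an 8.4-fold higher number from compound 2 to compound 4 (0.92 log units; beyond the scatter) lies beyond the scatter, and cyclohexyl does not match it here. Still open, on these data alone, is whether a ring amine such as piperidine, or fluoro on the cyclohexyl, would move the number in either direction. Nothing at hand gives a reason for these steps.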